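Swapping furan for thiophene on a fatty-acid amide hydrolase inhibitor

A few compounds are considered here, and "the series" means these few. Any claim that something is new, unique, unknown or untested is made for them only; others in the source may bear on it.

Compound 1, `O=C(CCCCCCc1ccccc1)c1ncno1`, in an assay for inhibition of Fatty-acid amide hydrolase 1 (Rattus norvegicus), at pH 9.0 (a lower number here means a stronger inhibitor, a higher number a weaker inhibitor), gives 1 nM.
Compound 2, `O=C(CCCCCCc1ccccc1)c1nc(-c2ccco2)no1`, in this assay gives 1 nM.

Compound 2 stands level with compound 1: the step of no change at the digits printed from compound 1 to compound 2 (within the scatter) shows that adding the furan ring did nothing beyond the scatter. Compound 3, `O=C(CCCCCCc1ccccc1)c1nc(-c2cccs2)no1`, differs from compound 2 by thiophen-2-yl in place of furan-2-yl on an aromatic carbon. Among the compounds with values here, no measured pair covers a swap of one five-membered ring for another, so the only guide is that the ring itself was neutral in the step from compound 1 to compound 2. The expected step is no change at the digits printed from compound 2 to compound 3 (within the scatter). For compound 3 the estimate is 1 nM, with a range from 0.4 nM to 2.5 nM.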

Compound 3, inhibition constant: 1.6 nM
For compound 3 the middle estimate is 1.6-fold (0.20 log units) below the measured one; measured number inside the range.
By their numbers in this assay, from the lowest: compounds 1, 2 and 3 (each within the scatter of the next).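

In this assay, thiophen-2-yl in place of furan-2-yl gives a 1.6-fold higher number from compound 2 to compound 3 (0.20 log units; within the scatter), so this aromatic carbon takes either five-membered aromatic ring, with oxygen or with sulfur in it. Thiophen-2-yl in place of hydrogen gives a 1.6-fold higher number from compound 1 to compound 3 (0.20 log units; within the scatter), so a second ring now matches the bare hydrogen at this position. Nothing available explains why these groups read alike.

From the compounds shown here alone, whether an amine or a carboxylic acid on this carbon would read the same stays open. So does whether either ring would stay level with hydrogen on a longer chain.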